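The source may report more compounds than this note shows. Statements on the series, on what has been measured and on what is new or still open speak of the compounds shown alone.

Three compounds built on a shared core have values in a functional assay on K562 cells (Homo sapiens) for inhibition, read by trypan blue exclusion, with a stated time of 72 h; on this read-out lower numbers stand for stronger inhibition and higher numbers for weaker inhibition. Compound 1 (`Cn1c(=O)c(S(=O)(=O)c2ccc(F)cc2F)cc2cnc(Nc3ccc4sccc4c3)nc21`) gives 500 nM, the second highest of the three numbers. Compound 2 (`Cn1c(=O)c(S(=O)(=O)c2ccc(F)cc2)cc2cnc(Nc3ccc4[nH]ccc4c3)nc21`) gives 200 nM, a lower number beyond the scatter, and compound 3 (`COc1ccc(S(=O)(=O)c2cc3cnc(Nc4cccc5[nH]ccc45)nc3n(C)c2=O)cc1`) gives 5000 nM, a higher number beyond the scatter.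

Compound 4 (`Cn1c(=O)c(S(=O)(=O)c2ccc(F)cc2F)cc2cnc(Nc3cnc4[nH]ccc4c3)nc21`) keeps the core of compound 1 and changes one group, on a nitrogen on an aromatic ring: a group of 9 heavy atoms (7 carbon, 2 nitrogen; one five-membered aromatic ring with 1 hetero atom, one six-membered aromatic ring with 1 hetero atom) in place of a group of 9 heavy atoms (8 carbon, 1 sulfur; one five-membered aromatic ring with 1 hetero atom, one six-membered aromatic ring of carbon only), on a nitrogen on an aromatic ring. For the measured compounds named here, no two measured compounds differ in one place, so this assay offers no direct precedent for this change. The closest guides disagree: compound 2 sits at 200 nM, while compound 3 sits at 5000 nM, and each also differs from compound 1 elsewhere. The expectation is therefore a small move towards a lower number, which may well stay within the scatter. The expected change is a 1.7-fold lower number from compound 1 to compound 4 (0.22 log units; within the scatter), an estimate only. For compound 4 the estimated value is 300 nM, with an expected range of 80 nM to 1200 nM.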

Compound 4, half-maximal inhibitory concentration: 750 nM
The estimate for compound 4 lay 2.5-fold (0.40 log units) below the measured number; measured number inside the range.
By their numbers in this assay, from the lowest: compound 2; then compounds 1 and 4 (each within the scatter of the next); then compound 3.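

In this assay, this position, on a nitrogen on an aromatic ring, now has its first step that can be read: a 1.5-fold higher number from compound 1 to compound 4 (0.18 log units; within the scatter). With the rest of compound 1 held constant, 1-benzothiophen-5-yl and the entering group, which has a six-membered aromatic ring with 1 hetero atom and 1 hydrogen-bond donor, cannot be told apart on this read-out. The compounds shown include no measurement that would account for this result.

This single exchange does not show whether the same outcome would hold with a different group on the sulfonyl, since compound 2 and compound 3 each differ from compound 4 in more than one place. From the compounds shown here alone, the effect of a phenyl group carrying a piperazine at this position also remains open.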